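The compounds below may be only part of what the source reports. "The series", "measured", "known", "first", "only" and "open" are said of these compounds alone.

Compound 2 `O=c1ccoc2cc(OCc3cn(Cc4cccc(Cl)c4)nn3)ccc12` and its bromo counterpart, compound 1 `O=c1ccoc2cc(OCc3cn(Cc4cccc(Br)c4)nn3)ccc12`, share the same core and differ only in the halogen on the aromatic ring. In a functional assay on HeLa cells (Homo sapiens) for cytotoxicity, read by MTT assay, with a stated time of 48 h (a lower number here means a stronger inhibitor, a higher number a weaker inhibitor), compound 1 gives no number, only the limit > 100000 nM. In this assay compound 2 likewise reaches only a limit, > 100000 nM. The step from one to the other, a step that the two limits leave unreadable from compound 1 to compound 2, therefore cannot be read, because of the limit of > 100000 nM in this assay, at which 2 of the 2 values shown sit. Compound 2 thus stands at the limit of this assay, with no number beneath it.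

Compound 3 `COc1ccc(Cn2cc(COc3ccc4c(=O)ccoc4c3)nn2)cc1` differs from compound 2 by 4-methoxyphenyl in place of 3-chlorophenyl on a saturated chain carbon bound to an aromatic nitrogen. Within the data shown here, no measured step bears on this change in a readable way: the single step that exists, a step that the two limits leave unreadable from compound 1 to compound 2, is itself unreadable, so nothing shows that any group at this place moves the read-out. The expectation for compound 3 in this assay is accordingly that it, too, will most likely return a limit rather than a number.

Compound 3 is expected to give about 150000 nM, within 40000 nM to 600000 nM. The step that the limit leaves unreadable from compound 2 to compound 3 is expected to stay unreadable against the limit.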

Compound 3, half-maximal inhibitory concentration: 14400 nM
Compound 3: middle estimate off by 10-fold (1.02 log units), on the high side, outside the stated range (below it).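

Compounds 1 and 2 could not show that this place on a saturated chain carbon bound to an aromatic nitrogen matters at all, but compound 3 does: in this assay, 4-methoxyphenyl in place of 3-chlorophenyl gives an at least 6.9-fold lower number from compound 2 to compound 3 (0.84 log units; beyond the scatter). The same holds against the bromo compound, with 4-methoxyphenyl in place of 3-bromophenyl giving an at least 6.9-fold lower number from compound 1 to compound 3 (0.84 log units; beyond the scatter), so the read-out at this place responds to the group it carries and the shared core alone does not fix it at the limit. Each of these steps gives only the smallest size the data allow, and its true size remains unknown, because the halogen compounds supply a limit and not a number: the limit of > 100000 nM in this assay, at which 2 of the 3 values shown sit.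

The change alters both the substituent and the way it is named on the ring, 3-halo against 4-methoxy, so the compounds shown do not separate the contribution of the methoxy group from that of its place. Also open, going by these compounds, is how this assay would read with an amine or a carboxylic acid in place of the methoxy group, or with a longer chain in place of the benzyl link.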